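The compounds below may be only part of what the source reports. "The series", "measured", "known", "first", "only" and "open" are said of these compounds alone.

Measured compounds in the set:
Compound 1 `Nc1n[nH]c2cc(-c3ccc(=O)n(Cc4ccccc4)c3)ccc12`: in an assay for inhibition of MAP kinase-interacting serine/threonine-protein kinase 2 (Homo sapiens), read by luminescence and ADP-Glo, with a stated time of 2 h (a lower number here means a stronger inhibitor, a higher number a weaker inhibitor), compound 1 gives 32 nM.
Compound 2 `O=c1ccc(-c2ccc3cn[nH]c3c2)cn1Cc1cccc(C(F)(F)F)c1`: in this assay compound 2 gives 32 nM.
Compound 3 `Cn1cc2ccc(-c3ccc(=O)n(Cc4ccccc4)c3)cc2n1`: in this assay compound 3 reports only a limit, > 2000 nM.

Compound 2 stands level with compound 1 at the digits reported, and the two values lie within the scatter of repeated measurements, so no difference between them can be read from these numbers. For compound 3 the assay gives a limit and no number, (the limit of > 2000 nM in this assay, at which 1 of the 3 values shown sits).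

The step followed here runs from compound 2 to compound 4 `O=c1ccc(-c2ccc3cn[nH]c3c2)cn1Cc1cccc(Cl)c1`, which has not yet been measured in this assay. The change is chloro in place of trifluoromethyl on an aromatic carbon. Among the measured compounds shown here, no step between two measured compounds of this kind is available, so its size must be judged from the change itself. Only a modest step is expected, within or barely beyond the scatter, and not in a firmly known direction. The estimate for compound 4 in this assay is 45 nM, with an expected range from 15 nM to 150 nM. That estimate means an expected step of a 1.4-fold higher number from compound 2 to compound 4 (0.15 log units; within the scatter).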

Compound 4, half-maximal inhibitory concentration: 40 nM
For compound 4 the middle estimate is 1.1-fold (0.05 log units) above the measured one; the measured number falls inside the stated range.
By their numbers in this assay, from the lowest: compounds 1, 2 and 4 (each within the scatter of the next). At a limit, above all of these: compound 3.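

Among the compounds shown here, exchanging trifluoromethyl for chloro gives a 1.3-fold higher number from compound 2 to compound 4 (0.10 log units; within the scatter) in this assay, and this is the first pair in the set that differs in only one place. On this aromatic carbon, meta to a large group, the pair therefore shows no difference between the two groups, so either one is compatible with a value in the range of compound 2 and compound 4. Nothing given here accounts for this result in terms of a measured property of either group.

On these data alone, whether this place accepts groups of another kind, such as a methoxy group, a nitrile or an amine, remains open. As far as these compounds go, it is also open how a chloro or trifluoromethyl group at this place would read out on the core of compound 1, which carries an amino group.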